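The source may report more compounds than this note shows. Statements on the series, on what has been measured and on what is new or still open speak of the compounds shown alone.

Two compounds of the series have been run in an ADME assay on NIH3T3 cells (Homo sapiens) for cytotoxicity, read by sulforhodamine B assay, with a stated time of 48 h; a lower number here means a stronger inhibitor, a higher number a weaker inhibitor. Compound 1 `CC(=O)OC[C@H]1O[C@@H](n2cc(CN3C(=O)/C(=C\c4ccccc4)c4ccccc43)nn2)[C@H](OC(C)=O)[C@@H](OC(C)=O)[C@@H]1OC(C)=O` gives 22800 nM. Compound 2 `CC(=O)OC[C@H]1O[C@@H](n2cc(CN3C(=O)/C(=C\c4ccc(N(C)C)cc4)c4ccccc43)nn2)[C@H](OC(C)=O)[C@@H](OC(C)=O)[C@@H]1OC(C)=O` gives 17000 nM. Among the measured compounds shown here, on the numbers so far compound 2 holds the lowest of two values, its only neighbour being compound 1, and the step of a 1.3-fold lower number from compound 1 to compound 2 (0.13 log units; within the scatter) lies within the scatter, so no order between the two is claimed. Compound 3 `CC(=O)OC[C@H]1O[C@@H](n2cc(CN3C(=O)/C(=C\c4cccs4)c4ccccc43)nn2)[C@H](OC(C)=O)[C@@H](OC(C)=O)[C@@H]1OC(C)=O` differs from compound 2 by thiophen-2-yl in place of 4-(dimethylamino)phenyl on a double-bonded chain carbon bound to a double-bonded ring carbon. For the measured compounds named here, no measured step exchanges one aromatic ring for another at this position; the only step recorded, a 1.3-fold lower number from compound 1 to compound 2 (0.13 log units; within the scatter), concerns a substituent on that ring and stayed within the scatter. Compound 3 is therefore expected to give a number close to that of its neighbour in this assay. The step of a 1.2-fold higher number from compound 2 to compound 3 (0.07 log units; within the scatter) is expected to stay within the scatter. The estimate for compound 3 is 20000 nM, with a range from 8000 nM to 50000 nM.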

Compound 3, half-maximal inhibitory concentration: 14600 nM
Compound 3: middle estimate off by 1.4-fold (0.14 log units), on the high side; measured number inside the range.
By their numbers in this assay, from the lowest: compounds 3, 2 and 1 (each within the scatter of the next).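

In this assay, the aromatic ring itself on the double-bonded chain carbon bound to a double-bonded ring carbon is now exchanged, where the earlier step changed only a substituent on that ring. Thiophen-2-yl in place of 4-(dimethylamino)phenyl gives a 1.2-fold lower number from compound 2 to compound 3 (0.07 log units; within the scatter), and thiophen-2-yl in place of phenyl gives a 1.6-fold lower number from compound 1 to compound 3 (0.19 log units; within the scatter), so a five-membered aromatic ring with one hetero atom is not separated from either six-membered ring, and no order among the three compounds can be claimed. No evidence bearing on this result is at hand.

From the compounds shown here alone, whether a saturated ring such as cyclohexyl, or a carboxylic acid on the phenyl ring, would move the number beyond the scatter at this place stays open. Also open, going by these compounds, is the effect of changes elsewhere on the shared core, such as removing the acetyl groups.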